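This account rests on a few compounds, and the source may have more. Where it says the series, first, only, none or still open, it means among the compounds named here.

Measured compounds:
- compound 1, `CN1CCN(c2nc(Cl)nc3c2ncn3Cc2ccc(C(=O)Nc3ccccc3N)cc2)CC1`: 13.5%
- compound 2, `CCC(C)n1cnc2c(NCc3ccc(C(=O)Nc4ccccc4N)cc3)nc(Cl)nc21`: 47.3%
- compound 3, `CCCn1cnc2c(NCc3ccc(C(=O)Nc4ccccc4N)cc3)nc(Cl)nc21`: 31%

These three compounds were tested in a functional assay on NCI-H460 cells (Homo sapiens) for antiproliferative activity, read by CCK-8 assay, with a stated time of 72 h, tested at 2 uM; a lower number here means a weaker effect, a higher number a stronger effect of the compound at the concentration tested. Compound 1 stands lowest of the three numbers in this assay: compound 3 is nearer to it, and compound 2 is furthest away, both beyond the scatter. Among the compounds with values here, the only step between two compounds that differ in one place is a number 16.3 percentage points lower from compound 2 to compound 3 (beyond the scatter), a modest drop.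

Compound 4, `CC1CCN(c2nc(Cl)nc3c2ncn3Cc2ccc(C(=O)Nc3ccccc3N)cc2)CC1`, is not yet measured. It differs from compound 1 by 4-methylpiperidin-1-yl in place of 4-methylpiperazin-1-yl on an aromatic carbon; the place is on an aromatic carbon of the six-membered aromatic ring with two nitrogen atoms in the shared core, next to the ring nitrogen and meta to the chloro group. Within the data shown here, the one measured step concerns a methyl on a saturated chain carbon and has no direct bearing on this exchange of one saturated ring for another. Among the measured compounds shown here, with no step that speaks to it, the expected change from compound 1 to compound 4 in this assay is small, a number 6.5 percentage points higher from compound 1 to compound 4 (within the scatter), and may well lie within the scatter. Compound 4 is therefore estimated at 20%, within 5% to 40%.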

Compound 4, a percentage reported as inhibition, at one concentration (the size of the read-out at that concentration, not a potency): 11.8%
Compound 4: middle estimate off by 8.2 percentage points, on the high side; measured number inside the range.
By their numbers in this assay, from the lowest: compounds 4 and 1 (each within the scatter of the next); then compound 3; then compound 2.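

In this assay, 4-methylpiperidin-1-yl in place of 4-methylpiperazin-1-yl gives a number 1.7 percentage points lower from compound 1 to compound 4 (within the scatter), so this exchange on an aromatic carbon of the shared core leaves the read-out within the usual scatter. The entering ring has one hetero atom and one hydrogen-bond acceptor where the leaving ring has two of each, and at this concentration that difference produces no change that can be told from scatter. No measurement here explains this outcome or shows what either ring does in the cells.

Still open, from the compounds shown here alone, is whether a ring of another kind at this place, such as morpholine, or an open-chain group such as dimethylamino, would read differently. Going by these compounds, both rings here also carry a methyl group, so the effect of removing it or replacing it with a longer chain remains unknown.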